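Trimming the Anilide Side Chain: Compound 1 to Compound 4

The source may report more compounds than this note shows. Statements on the series, on what has been measured and on what is new or still open speak of the compounds shown alone.

Measured compounds in an assay on isolated protein for agonist activity at transient receptor potential cation channel subfamily M member 8 (Homo sapiens), read by fluorescence; on this read-out lower numbers stand for an effect already at smaller amounts and higher numbers for an effect only at larger amounts of compound:
compound 1 `COc1ccc(NC(=O)[C@@H]2C[C@H](C)CC[C@H]2C(C)C)c(NC(=O)[C@@H](C)N)c1`: 3000 nM
compound 2 `COc1ccc2c(c1)n(CCN)c(=O)n2C(=O)[C@@H]1C[C@H](C)CC[C@H]1C(C)C`: < 5000 nM
compound 3 `C=CCc1cc(OC)c(OC(C)C(O[C@@H]2C[C@H](C)CC[C@H]2C(C)C)c2ccc(OC)c(OC)c2)c(OC)c1`: 10000 nM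

Three compounds share the menthane-derived core. In this assay compound 1 gives 3000 nM, the lowest of the two plain numbers. Compound 3, with the core joined through an ether, gives 10000 nM, a higher number, and the gap to compound 1 lies beyond the usual scatter. For compound 2 the read-out is only a limit, (the limit of < 5000 nM in this assay, at which 1 of the 3 values shown sits), and no number can be set against it.

The unmeasured compound 4 `COc1ccc(NC(=O)[C@@H]2C[C@H](C)CC[C@H]2C(C)C)cc1` is compound 1 with one change: hydrogen in place of ((1-aminoethyl)carbonyl)amino on an aromatic carbon. What remains is the anilide of the core carrying a single methoxy group. Going by the values given here, no measured pair shows a step of this kind, so no recorded step can be pointed to. Still, compound 4 is the simpler, smaller anilide, and the account expects its number in this assay to be lower than that of compound 1, a step toward an effect at smaller amounts, a 20-fold lower number from compound 1 to compound 4 (1.30 log units; beyond the scatter), well beyond the scatter. The estimate for compound 4 is 150 nM, with a range from 20 nM to 1500 nM, an estimate and not a measurement.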

Compound 4, half-maximal effective concentration: 12000 nM
Compound 4: the middle estimate sits 80-fold (1.90 log units) below what was measured; the measured number lies above the stated range.
By their numbers in this assay, from the lowest: compound 1; then compounds 3 and 4 (each within the scatter of the next).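

On this aromatic carbon, ortho to a large group and meta to a methoxy group, the ((1-aminoethyl)carbonyl)amino group makes a measurable difference in this assay: replacing it with hydrogen gives a 4.0-fold higher number from compound 1 to compound 4 (0.60 log units; beyond the scatter) and is a modest step. Going by these compounds alone, the side chain of compound 1 is therefore no burden on this read-out, since the simpler anilide, compound 4, shows its effect only at larger amounts, something the earlier compounds could not show because no measured pair among them differed in one place. The measurements at hand offer no explanation for the direction or the size of this step.

What stays open is whether the whole ((1-aminoethyl)carbonyl)amino group is needed or only a part of it, as the compounds shown do not tell how a plain amino group or an acetylamino group would read on the same carbon. They also leave open how a longer chain ending in an amine, or the opposite configuration at the defined stereocentre of the side chain, would compare with compound 1.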